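Alkylamino variation on two halogenated cores in rat aorta

The source may hold more compounds than are shown below. What is called first, only, known or untested is meant among the compounds shown, and "the series" means these compounds.

Measured compounds:
compound 1, `CCCNC1=NS(=O)(=O)c2cc(F)ccc2N1`, 166 uM
compound 2, `CCC(C)NC1=NS(=O)(=O)c2cc(F)ccc2N1`, 39.2 uM
compound 3, `CCNC1=NS(=O)(=O)c2cc(Cl)ccc2N1`, 39.9 uM

Three compounds were measured in a functional assay (aorta) with Rattus norvegicus as the target; a higher number here means that more compound is needed for the effect, a lower number that less compound is needed. Compound 1, `CCCNC1=NS(=O)(=O)c2cc(F)ccc2N1`, gives 166 uM, and compound 2, `CCC(C)NC1=NS(=O)(=O)c2cc(F)ccc2N1`, gives 39.2 uM. The change between them is methyl in place of hydrogen on a saturated chain carbon bound to an amine nitrogen and a saturated chain carbon, and it produced a 4.2-fold lower number from compound 1 to compound 2 (0.63 log units; beyond the scatter). Compound 3, `CCNC1=NS(=O)(=O)c2cc(Cl)ccc2N1`, gives 39.9 uM in this assay, a number within the scatter of compound 2; the difference between the core of compound 3 and the core of compound 1 is not broken down here.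

Compound 4, `CCCNC1=NS(=O)(=O)c2cc(Cl)ccc2N1`, has not yet been measured in this assay. It differs from compound 3 by methyl in place of hydrogen on a saturated chain carbon, two bonds along the chain from an amine nitrogen. Going by the values given here, this is the same kind of change as the one from compound 1 to compound 2, but not the same: there the methyl entered on a saturated chain carbon bound to an amine nitrogen and a saturated chain carbon, whereas here it enters on a saturated chain carbon two bonds along the chain from an amine nitrogen. Among the compounds with values here, no measured pair shows this exact step on either core. Within the data shown here, the step from compound 1 to compound 2 is the only guide. It sits at a different place in the chain, and it cannot simply be carried over. The step from compound 3 to compound 4 is therefore expected to be small, around a 1.4-fold higher number from compound 3 to compound 4 (0.14 log units; within the scatter), within or near the scatter. Compound 4 is estimated to give about 55 uM in this assay, most likely between 20 uM and 150 uM.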

Compound 4, concentration for half-maximal effect: 55.5 uM
For compound 4 the middle estimate is 1.0-fold (0.00 log units) below the measured one; the range from low to high includes it.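

In this assay the added methyl gives a 1.4-fold higher number from compound 3 to compound 4 (0.14 log units; within the scatter), which does not repeat the earlier methyl step on the fluoro core, and the two steps differ: the same change on two cores in this assay, a 4.2-fold lower number (0.63 log units; beyond the scatter) from compound 1 to compound 2 and a 1.4-fold higher number (0.14 log units; within the scatter) from compound 3 to compound 4, 5.9-fold (0.77 log units) apart, beyond the scatter of two such steps

A methyl step that pays on one core therefore cannot be assumed to pay on the other in this series, and the choice of core itself counts here: with the propylamino chain kept, chloro in place of fluoro gives a 3.0-fold lower number from compound 1 to compound 4 (0.48 log units; beyond the scatter). What this does not show is that the core alone sets the size of the methyl step, as the methyl enters at a different place in the chain in the two steps and each step rests on a single pair, which leaves the effects of core and place unseparated.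

The compounds shown leave open whether a methyl on the carbon bound to the amine nitrogen would give a similar step on the chloro core, and where the ethylamino compound on the fluoro core would stand. They also say nothing about how a longer chain, a cyclic amine or a bromo group in place of the halogen would read in this series.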